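Swapping One Aryl Group on a Growth Inhibitor

This account rests on a few compounds, and the source may have more. Where it says the series, first, only, none or still open, it means among the compounds named here.

Measured so far in a functional assay on DU-145 cells (Homo sapiens) for inhibition, read by trypan blue exclusion, with a stated time of 96 h; on this read-out higher numbers stand for weaker inhibition of growth and lower numbers for stronger inhibition of growth
Compound 1 `COc1ccccc1/C=C(/SCc1ccc(F)cc1)C(=O)c1ccc(Br)cc1` gives 10000 nM
Compound 2 `COc1cc(/C=C(/SCc2ccc(Br)cc2)C(=O)c2ccc(C(=O)O)cc2)ccc1F` gives 1000 nM

Compound 2 holds the lower of the two numbers at 1000 nM and the gap up to compound 1 lies beyond the usual scatter. Compound 3 `O=C(O)c1ccc(C(=O)/C(=C\c2ccccc2F)SCc2ccc(Br)cc2)cc1` has not yet been measured. It differs from compound 2 by 2-fluorophenyl in place of 4-fluoro-3-methoxyphenyl on a double-bonded chain carbon bound to a double-bonded chain carbon with 2-fluorophenyl in place of 4-fluoro-3-methoxyphenyl on a double-bonded chain carbon bound to a double-bonded chain carbon. Within the data shown here, no measured pair shows this change alone, so only a small move towards higher numbers in this assay is expected, within the scatter. The expected change is a 1.5-fold higher number from compound 2 to compound 3 (0.18 log units; within the scatter) for now. For compound 3 the estimate is 1500 nM with an expected range of 500 nM to 5000 nM until a measurement exists.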

Compound 3, concentration for 50% growth inhibition: 10000 nM
Beside the measured number, compound 3's estimate is 6.7-fold (0.82 log units) below it, and the stated range ends below it.
By their numbers in this assay, from the lowest: compound 2; then compounds 1 and 3 (each within the scatter of the next).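

In this assay, among these compounds, 2-fluorophenyl in place of 4-fluoro-3-methoxyphenyl gives a 10-fold higher number from compound 2 to compound 3 (1.00 log units; beyond the scatter), the first single change in this set, and it shows that growth inhibition responds to the aryl group at this position. Both groups carry one aromatic ring of carbon and one fluorine, so these shared features alone do not preserve the lower number. No available evidence explains this step. Still open, on these data alone, is whether the methoxy group or the placing of the fluorine carries the difference, and how an amine on this aryl group would read out.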